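The source may hold more compounds than are shown below. What is called first, only, known or untested is meant among the compounds shown, and "the series" means these compounds.

Of the compounds shown here, two that share one core have been measured. Compound 1 `CS(=O)(=O)c1cc(C#N)ccc1C(=O)N1CCC(N(C2CC2)S(=O)(=O)c2cccc(C(F)(F)F)c2)CC1` and compound 2 `CS(=O)(=O)c1cc(C(F)(F)F)ccc1C(=O)N1CCC(N(C2CC2)S(=O)(=O)c2cccc(C(F)(F)F)c2)CC1` differ at a single aromatic carbon, where compound 2 carries a trifluoromethyl in place of the cyano of compound 1. In an assay on HEK293 cells for inhibition of Voltage-dependent N-type calcium channel subunit alpha-1B (Homo sapiens), read by FLIPR and calcium flux (on this read-out higher numbers stand for weaker inhibition and lower numbers for stronger inhibition), compound 1 gives 450 nM, and compound 2 gives 27 nM. Among the measured compounds shown here, the step of a 17-fold lower number from compound 1 to compound 2 (1.22 log units; beyond the scatter) is the only measured step, and compound 1 stands at the higher of the two numbers. Compound 3 `CS(=O)(=O)c1ccc(C(=O)N2CCC(N(C3CC3)S(=O)(=O)c3cccc(C(F)(F)F)c3)CC2)c(F)c1` has not yet been measured in this assay. It differs from compound 1 as follows: 2-fluoro-4-(methylsulfonyl)phenyl in place of 4-cyano-2-(methylsulfonyl)phenyl on a carbonyl carbon. The measured step from compound 1 to compound 2 concerns the same aromatic ring and was large, but it exchanged one group while everything else on that ring stayed the same; in compound 3 the cyano is gone, a fluorine enters, and the arrangement of the groups on the ring changes, so that step offers only loose guidance. For the measured compounds named here, no measured step speaks directly to this change. For compound 3 the number in this assay is estimated at 600 nM, within a range from 150 nM to 2500 nM. This estimate means the step of a 1.3-fold higher number from compound 1 to compound 3 (0.12 log units; within the scatter) is expected to stay within the scatter.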

Compound 3, half-maximal inhibitory concentration: 350 nM
Compound 3: the middle estimate sits 1.7-fold (0.23 log units) above what was measured, within the range that was stated.
By their numbers in this assay, from the lowest: compound 2; then compounds 3 and 1 (each within the scatter of the next).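

Replacing the 4-cyano-2-(methylsulfonyl)phenyl on the carbonyl carbon with 2-fluoro-4-(methylsulfonyl)phenyl gives a 1.3-fold lower number from compound 1 to compound 3 (0.11 log units; within the scatter) in this assay and so leaves the two compounds indistinguishable, even though the nitrile is gone, a fluorine has entered and the groups on the ring are arranged differently. Among the compounds shown here, the earlier compounds showed only that exchanging one group on this ring can matter a great deal, with a 17-fold lower number from compound 1 to compound 2 (1.22 log units; beyond the scatter) as the single example; this result adds that a much wider rewrite of the same ring need not produce any readable change. No other measurement bears on this result, so the data offer no explanation for why one change moved the number so strongly and the other did not.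

The compounds shown do not separate the loss of the nitrile, the entry of the fluorine and the new arrangement of the groups from one another. Going by these compounds, it also stays open how other groups in place of the trifluoromethyl of compound 2, such as a methoxy, an amine or a carboxylic acid, would compare with compound 2, which gives 27 nM in this assay.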